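A few compounds are considered here, and "the series" means these few. Any claim that something is new, unique, unknown or untested is made for them only; others in the source may bear on it.

Compound 1, `CCCC(=O)Nc1ncc(-c2cccc(Cl)c2)c(-c2ccccc2)n1`, gives > 80% in an assay on CHO cells for displacement of a labelled ligand from adenosine receptor A1 (Homo sapiens), read by scintillation counting, with a stated time of 1 h, tested at 1 uM; on this read-out lower numbers stand for less inhibition and higher numbers for more inhibition at the one concentration tested (going by the name of the read-out); that value is a limit of the assay rather than a number (the limit of > 80% in this assay, at which 1 of the 3 values shown sits).
Compound 2, `CCCCC(=O)Nc1ncc(-c2cccc(Cl)c2)c(-c2ccccc2)n1`, gives 52% in this assay.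
Compound 3, `Clc1cccc(-c2cnc(Nc3ccccc3)nc2-c2ccccc2)c1`, gives 34% in this assay.

Among the plain numbers compound 3 stands lowest, since there is a number 18 percentage points lower from compound 2 to compound 3 (beyond the scatter). Compound 4, `Clc1cccc(-c2cnc(NC3CCCC3)nc2-c2ccccc2)c1`, is not yet measured; it differs from compound 3 by cyclopentyl in place of phenyl on a nitrogen on an aromatic ring. The measured steps that change the same nitrogen are a number at least 46 percentage points lower from compound 1 to compound 3 (beyond the scatter) and a number 18 percentage points lower from compound 2 to compound 3 (beyond the scatter), both swapping an acyl chain for phenyl, so they offer no direct guide to a cyclopentyl. The expectation is therefore a step of about a number 4 percentage points higher from compound 3 to compound 4 (within the scatter), with little confidence in its direction. For compound 4 the estimate in this assay is 38%, ranging from 15% to 65%.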

Compound 4, a percentage reported as inhibition, at one concentration (the size of the read-out at that concentration, not a potency): > 80%
Compound 4: a limit, no number (the forecaster's own chance of this, stated with the estimate: 5%); at least 42 percentage points between middle value and limit.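

In this assay there is a number at least 46 percentage points higher from compound 3 to compound 4 (beyond the scatter) on going from anilino to cyclopentylamino, so the kind of ring on this nitrogen matters, not merely the presence of a ring. An acyl group is not needed here either, with a number at least 28 percentage points higher from compound 2 to compound 4 (beyond the scatter) for cyclopentyl in place of butylcarbonyl. The value of compound 4 is a limit of the assay, and the step from compound 1 to compound 4 cannot be read: the limit of > 80% in this assay, at which 2 of the 4 values shown sit.

As far as these compounds go, whether a smaller ring such as cyclopropyl or a larger one such as cyclohexyl would hold this level stays open.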